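The source may report more compounds than this note shows. Statements on the series, on what has been measured and on what is new or still open speak of the compounds shown alone.

Compounds measured in an in vivo functional assay on the whole organism for inhibition of 3-hydroxy-3-methylglutaryl-coenzyme A reductase (Rattus norvegicus), at a dose of 0.2 mg/kg by the oral route; on this read-out higher numbers stand for a stronger effect at the one dose given and lower numbers for a weaker effect:
compound 1, `Cc1nn(C(C)(C)C)c2nc(C3CC3)c(/C=C/[C@@H](O)C[C@@H](O)CC(=O)O)c(-c3ccc(F)cc3)c12`: 4.5%
compound 2, `Cc1nn(C(C)(C)C)c2nc(C(C)C)c(/C=C/[C@@H](O)C[C@@H](O)CC(=O)O)c(-c3ccc(F)cc3)c12`: 51.8%
compound 3, `CC(C)c1nc2c(c(-c3ccccc3)nn2C)c(-c2ccc(F)cc2)c1/C=C/[C@@H](O)C[C@@H](O)CC(=O)O`: 37%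

The change from compound 2 to compound 1 is cyclopropyl in place of isopropyl on an aromatic carbon. In this assay it gives a number 47.3 percentage points lower from compound 2 to compound 1 (beyond the scatter). Compound 3 and compound 2 have different cores; that difference is not broken down here. On its own core compound 3 stands between the other two.

Compound 4, `Cn1nc(-c2ccccc2)c2c(-c3ccc(F)cc3)c(/C=C/[C@@H](O)C[C@@H](O)CC(=O)O)c(C3CC3)nc21`, is not yet measured. It arises from compound 3 by cyclopropyl in place of isopropyl on an aromatic carbon, the same change seen between compound 2 and compound 1. For compound 4 in this assay a step of a number 32 percentage points lower from compound 3 to compound 4 (beyond the scatter) is expected, resting on a number 47.3 percentage points lower from compound 2 to compound 1 (beyond the scatter). Since compound 3 gives only 37%, a drop of the earlier size would use up most of what compound 3 shows, so the expected step is smaller than the earlier one. Compound 4 is therefore estimated at 5%, most likely between 0% and 20%.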

Compound 4, a percentage reported as inhibition, in the whole organism at one dose (the size of the read-out at that dose, not a potency): -54.4%
Estimate against measurement, compound 4: 59.4 percentage points above; the measured number lies below the stated range.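

In this assay, cyclopropyl in place of isopropyl on the second core gives a number 91.4 percentage points lower from compound 3 to compound 4 (beyond the scatter), and set beside the first core the direction of the step holds while its size does not: the same change on two cores in this assay, a number 47.3 percentage points lower (beyond the scatter) from compound 2 to compound 1 and a number 91.4 percentage points lower (beyond the scatter) from compound 3 to compound 4, 44.1 percentage points apart, beyond the scatter of two such steps So the change lowers the read-out on both cores shown, but the size of the step on one core cannot be carried over to the other. With a single pair on each core, these results do not show why the two steps differ, or what the change would do on a further core.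

As far as these compounds go, it remains open how an ethyl group or a cyclobutyl ring in the same place would fare on either core. Also open, from the compounds shown here alone, is whether an amine or a longer chain there would keep the read-out of compound 2 or of compound 3.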